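Ether-linked pyrrolidine series on ovarian cancer cells

The source may report more compounds than this note shows. Statements on the series, on what has been measured and on what is new or still open speak of the compounds shown alone.

Measured so far:
compound 1 `c1ccc(COc2ccc(OCCOCCOC3CCCC3)cc2)cc1` — > 100000 nM
compound 2 `COc1ccc(COc2ccc(OCCOCCNC3CCCC3)cc2)cc1` — 15700 nM

In a functional assay on SK-OV-3 cells (Homo sapiens) for inhibition, read by CCK-8 assay, with a stated time of 70 h (on this read-out higher numbers stand for weaker inhibition and lower numbers for stronger inhibition), compound 1 gives > 100000 nM, which is a limit of the assay and not a number (the limit of > 100000 nM in this assay, at which 1 of the 2 values shown sits). In this assay, for the measured compounds named here, compound 2 gives 15700 nM, the only number among the values shown, so compound 2 stands as the single measured point of reference.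

Compound 3 `COC(=O)c1ccccc1COc1ccc(OCCOCCNC2CCCC2)cc1` has not yet been measured. It differs from compound 2 in one place: 2-(methoxycarbonyl)phenyl in place of 4-methoxyphenyl on a saturated chain carbon bound to an oxygen on an aromatic ring. The pyrrolidine-bearing chain and the central aromatic ether are kept.

Going by the values given here, no step between two measured compounds is available, so the size of this change cannot be read from the data. The expectation is a step of no more than the usual scatter in this assay, with no clear direction, so that compound 3 is estimated close to compound 2 with the step of a 1.0-fold lower number from compound 2 to compound 3 (0.02 log units; within the scatter). On this basis compound 3 is expected at 15000 nM, within 4000 nM to 60000 nM.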

Compound 3, half-maximal inhibitory concentration: > 100000 nM
Compound 3 was reported as a limit (the forecaster's own chance of this, stated with the estimate: 15%); at least 6.6-fold (0.82 log units) between middle value and limit.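

In this assay, 2-(methoxycarbonyl)phenyl in place of 4-methoxyphenyl on a saturated chain carbon bound to an oxygen on an aromatic ring gives an at least 6.3-fold higher number from compound 2 to compound 3 (0.80 log units; beyond the scatter). For the compounds shown here, this is the first step that can be read, and it shows that the measurable inhibition of compound 2 does not survive every exchange of the aryl group at this position, even with the chain and the central aromatic ether kept. Compound 3 gives > 100000 nM, which is a limit of the assay and not a number, and the series still has a single measured value as its point of reference: the limit of > 100000 nM in this assay, at which 2 of the 3 values shown sit.

Going by these compounds, it remains open whether the loss follows the methoxycarbonyl group itself or the exchange of the aryl group as a whole; a plain phenyl on the same amine-bearing chain, or a carboxylic acid or primary amide in place of the ester, would help to separate the two. The compounds shown also give no readable step for any change at the amine end of the chain, so the contribution of that part to the value of compound 2 is unknown.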